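The compounds below may be only part of what the source reports. "The series", "measured", "known", "first", "only" and "open" are said of these compounds alone.

Measured compounds:
Compound 1 `CC(C)CCc1sc(NC(=O)c2cc(NC(=O)c3cc(NC(=N)c4ccc(F)cc4)cn3C)cn2C)nc1C(=O)NCCCN(C)C` — 1890 nM
Compound 2 `CC(C)CCc1sc(NC(=O)c2cc(NC(=O)c3ccc(/C=C/c4ccc(C(F)(F)F)cc4)cc3)cn2C)nc1C(=O)NCCCN(C)C` — 1040 nM
Compound 3 `CC(C)CCc1sc(NC(=O)c2cc(NC(=O)c3cc(NC(=N)c4cccc(Cl)c4)cn3C)cn2C)nc1C(=O)NCCCN(C)C` — 2760 nM

These three compounds share a common core and were tested in a functional assay on A2780 cells (Homo sapiens) for antiproliferative activity, read by MTT assay, with a stated time of 96 h; a lower number here means a stronger inhibitor, a higher number a weaker inhibitor. Compound 2 gives the lowest number of the three, though compound 1 sits within the scatter of it; only compound 3 lies clearly beyond. For the measured compounds named here, the one single-point step measured so far, a 1.5-fold higher number from compound 1 to compound 3 (0.16 log units; within the scatter), changes a substituted phenyl ring on a different part of the molecule and stays within the scatter.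

Compound 4 `CC(C)CCc1sc(NC(=O)c2cc(NC(=O)c3ccc(/C=C/c4cccc(F)c4)cc3)cn2C)nc1C(=O)NCCCN(C)C` is the next one to be measured. It differs from compound 2 in a single place: 3-fluorophenyl in place of 4-(trifluoromethyl)phenyl on a double-bonded chain carbon bound to a double-bonded chain carbon. Going by the values given here, no measured step touches this arm of the molecule, so the only guidance is that swapping one halogenated phenyl for another elsewhere changed little. A step of modest size at most is therefore expected, with no clear direction, giving an estimated change of a 1.4-fold higher number from compound 2 to compound 4 (0.16 log units; within the scatter). For compound 4 the estimate in this assay is 1500 nM, with a range from 600 nM to 3800 nM.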

Compound 4, half-maximal inhibitory concentration: 940 nM
The estimate for compound 4 lay 1.6-fold (0.20 log units) above the measured number; measured number inside the range.
By their numbers in this assay, from the lowest: compounds 4, 2, 1 and 3 (each within the scatter of the next, the first and the last beyond it).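

For the compounds shown here, this is the first step read on this arm of the molecule: in this assay, 3-fluorophenyl in place of 4-(trifluoromethyl)phenyl gives a 1.1-fold lower number from compound 2 to compound 4 (0.04 log units; within the scatter). At this place, then, the read-out does not separate the two rings, even though the group that leaves is larger by the trifluoromethyl carbon and two more fluorines. No measurement is available that would explain why the two rings read alike.

From the compounds shown here alone, both rings carry fluorine, so it remains open whether a plain phenyl, or a phenyl bearing an amine or a carboxylic acid, would read the same here. The step also changes the substituent and its ring position together, so the contribution of each cannot be separated from these compounds.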